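Swapping a Methoxy for a Methylpiperazine on a Shared Core

A few compounds are considered here, and "the series" means these few. Any claim that something is new, unique, unknown or untested is made for them only; others in the source may bear on it.

Measured so far:
compound 1, `Nc1n[nH]c2cc(-c3ccccn3)[nH]c(=O)c12`, giving 33% in an assay on isolated protein for inhibition of serine/threonine-protein kinase D2 (Homo sapiens), read by mobility shift assay, tested at 30 uM; on this read-out lower numbers stand for less inhibition and higher numbers for more inhibition at the one concentration tested (going by the name of the read-out)
compound 2, `COc1ccc(-c2cc3[nH]nc(N)c3c(=O)[nH]2)cc1`, giving 28% in this assay

For the measured compounds named here, only two compounds have numbers here, and both sit in a modest range. The gap between compound 2 and compound 1 falls within the usual scatter of this kind of measurement, so the two cannot be told apart. Going by the values given here, no step between measured compounds that differ in a single place exists in these data, so nothing measured yet shows how large a single change can move the read-out.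

Compound 3, `CN1CCN(c2ccc(-c3cc4[nH]nc(N)c4c(=O)[nH]3)cc2)CC1`, has not been measured. It differs from compound 2 in one place: 4-methylpiperazin-1-yl in place of methoxy on an aromatic carbon. Among the compounds with values here, with no measured step to lean on, the size of the change from compound 2 to compound 3 is expected to be small, in either direction or none beyond the scatter, and a slight rise is taken as the middle guess: a number 4 percentage points higher from compound 2 to compound 3 (within the scatter). Compound 3 is therefore estimated at 32%, within a range from 15% to 50%.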

Compound 3, a percentage reported as inhibition, at one concentration (the size of the read-out at that concentration, not a potency): 15%
Compound 3: middle estimate off by 17 percentage points, on the high side, and the stated range covers the measured number.
By their numbers in this assay, from the lowest: compound 3; then compounds 2 and 1 (each within the scatter of the next).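

For the compounds shown here, replacing methoxy with 4-methylpiperazin-1-yl gives a number 13 percentage points lower from compound 2 to compound 3 (beyond the scatter) in this assay, the first single change here to move the read-out by more than the usual scatter. This shows that the group on this aromatic carbon, para to a large group, is not a neutral choice, and that here a larger group carrying a six-membered non-aromatic ring goes with less inhibition at the one concentration tested. No measurement shown here accounts for the drop, so the reason stays unknown.

A single step changes many things at once, so it cannot separate the effect of losing methoxy from that of adding the ring, the ring nitrogens or the methyl on the ring. Morpholin-4-yl, piperazin-1-yl without the methyl, a simple dimethylamino group or a plain hydrogen at the same place would help to show which part of the change matters, and whether any group here can raise the read-out rather than lower it.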